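A few compounds are considered here, and "the series" means these few. Any claim that something is new, unique, unknown or untested is made for them only; others in the source may bear on it.

Measured compounds in a functional assay on CHO-K1 cells for antagonist activity at prostaglandin E2 receptor EP1 subtype (Homo sapiens), read by FLIPR; on this read-out higher numbers stand for weaker inhibition and lower numbers for stronger inhibition:
- compound 1 `O=C(O)c1ccn(Cc2cc(Br)ccc2OCc2ccccc2)n1`: 55 nM
- compound 2 `O=C(O)c1nn(Cc2cc(Br)ccc2OCc2ccccc2)cc1Cl`: only a limit of the assay, < 2000 nM
- compound 3 `Cc1cc(C(=O)O)nn1Cc1cc(Br)ccc1OCc1cccc(C(F)(F)F)c1`: 1100 nM

Of the two numbers, compound 3 stands higher, and the gap to compound 1 is beyond the scatter. The step that the limit leaves unreadable from compound 1 to compound 2 is the change (chloro in place of hydrogen on an aromatic carbon); its size cannot be read, because compound 2 sits at the limit of < 2000 nM in this assay, at which 1 of the 3 values shown sits. How the cores of compound 1 and compound 3 differ is not broken down here.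

Compound 4 `Cc1cc(C(=O)O)nn1Cc1cc(Br)ccc1OCc1ccc(Cl)c(C(F)(F)F)c1` is not yet measured. It differs from compound 3 by chloro in place of hydrogen on an aromatic carbon. This is the same kind of change as from compound 1 to compound 2, but not the same: there the chloro enters on a five-membered aromatic ring with 2 nitrogen, next to the ring atom that bears a carboxy group; here it enters on a six-membered aromatic ring of carbon only, ortho to a trifluoromethyl group and para to a large group. Within the data shown here, since the only measured instance of this change is unreadable, no direction is supported; the step from compound 3 is expected to be small, a 1.4-fold higher number from compound 3 to compound 4 (0.13 log units; within the scatter). For compound 4 the estimate is 1500 nM, expected between 500 nM and 5000 nM.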

Compound 4, inhibition constant: < 2000 nM
Compound 4: a limit, no number; the forecaster's own chance of this, stated with the estimate: 30%; the middle value lies beyond the limit too.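

Compound 4 gives only a limit in this assay, < 2000 nM, so no step from compound 3 to compound 4 can be read: the limit of < 2000 nM in this assay, at which 2 of the 4 values shown sit.

The compounds shown leave open both the size and the direction of the effect of chloro in place of hydrogen on an aromatic carbon, on either of the two rings concerned.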